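The source may report more compounds than this note shows. Statements on the series, on what has been measured and on what is new or still open speak of the compounds shown alone.

Measured compounds in a functional assay on HEK293 cells for antagonist activity at thromboxane A2 receptor (Homo sapiens), read by fluorescence and calcium flux; on this read-out higher numbers stand for weaker inhibition and lower numbers for stronger inhibition:

compound 1, `Cc1ccccc1Oc1ccc(C#N)cc1S(=O)(=O)NC(=O)NC(C)C`, gives 6130 nM
compound 2, `Cc1cccc(Oc2ccc(C#N)cc2S(=O)(=O)NC(=O)NC(C)C)c1`, gives 1690 nM
compound 3, `Cc1cccc(Nc2ccc(C#N)cc2S(=O)(=O)NC(=O)NC(C)C)c1`, gives 9110 nM

Compound 3 carries the highest number of the three in this assay, that is, the weakest inhibition. Its nearest neighbour is compound 1, where the step of a 1.5-fold higher number from compound 1 to compound 3 (0.17 log units; within the scatter) lies within the scatter, so the two cannot be told apart. The gap to compound 2 is clearer: the step of a 5.4-fold higher number from compound 2 to compound 3 (0.73 log units; beyond the scatter) goes beyond the scatter.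

Compound 4, `CC(C)NC(=O)NS(=O)(=O)c1cc(C#N)ccc1Nc1ccc(F)cc1`, differs from compound 3 in a single place: 4-fluorophenyl in place of 3-methylphenyl on a nitrogen on an aromatic ring. For the measured compounds named here, no measured step swaps one aryl group for another on the nitrogen, so none bears on this change directly. The closest comparison is the step of a 3.6-fold lower number from compound 1 to compound 2 (0.56 log units; beyond the scatter), where only the position of a methyl on the aryl ring attached to the oxygen was moved, and that alone gave a modest shift. This shows that the pattern on the outer aryl ring can matter, but it gives no direction for a fluorine in place of a methyl.

The expectation is therefore a step for compound 4 of a 1.2-fold lower number from compound 3 to compound 4 (0.08 log units; within the scatter) in this assay, likely within the scatter, with a wide margin either way. Compound 4 is estimated at 7500 nM, within a range from 2000 nM to 28000 nM.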

Compound 4, half-maximal inhibitory concentration: 7830 nM
For compound 4 the middle estimate is 1.0-fold (0.02 log units) below the measured one; measured number inside the range.
By their numbers in this assay, from the lowest: compound 2; then compounds 1, 4 and 3 (each within the scatter of the next).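

In this assay, the 3-methylphenyl and 4-fluorophenyl groups on this nitrogen cannot be told apart, with a 1.2-fold lower number from compound 3 to compound 4 (0.07 log units; within the scatter), so this swap changes both the ring's substituent and the printed number on its name without a readable effect on the result. For the compounds shown here, the 2-methylphenoxy compound also cannot be told apart from the new compound, at a 1.3-fold higher number from compound 1 to compound 4 (0.11 log units; within the scatter), whereas the 3-methylphenoxy compound stays clearly separate, at a 4.6-fold higher number from compound 2 to compound 4 (0.67 log units; beyond the scatter); with the stronger inhibition on the 3-methylphenoxy side, it remains the only compound of the four set apart from the others. Nothing available here accounts for these numbers.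

What remains open is whether the clear gap between the 3-methylphenoxy and (3-methylphenyl)amino compounds is specific to that pair, since a 4-fluorophenoxy partner for compound 4 is not among the compounds shown. It is also unclear how far this tolerance on the outer ring extends, as the compounds shown carry only a methyl or a fluorine there, leaving groups such as a carboxylic acid, an amine or a longer chain untested in this comparison.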